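This account rests on a few compounds, and the source may have more. Where it says the series, first, only, none or still open, it means among the compounds named here.

Compound 1 `COc1cc2ncnc(N3CCCc4ccccc43)c2cc1NC(=O)/C=C/CN1CCCCC1` and compound 2 `COc1cc2ncnc(N3CCCc4ccccc43)c2cc1NC(=O)/C=C/CN1CCN(C)CC1` share one core; compound 3 `O=C(/C=C/CN1CCCCC1)Nc1cc2c(N3CCCc4ccccc43)ncnc2cc1O[C@@H]1CCOC1` differs from compound 1 by oxolan-3-yl in place of methyl on an oxygen on an aromatic ring and so carries the second core. In a functional assay on A549 cells (Homo sapiens) for antiproliferative activity, read by MTT assay, with a stated time of 72 h (a higher number here means a weaker inhibitor, a lower number a stronger inhibitor), compound 1 gives 2880 nM. In this assay compound 2 gives 7830 nM, and compound 3 gives 3670 nM. The core change alone reads a 1.3-fold higher number from compound 1 to compound 3 (0.11 log units; within the scatter). The amine change reads a 2.7-fold higher number from compound 1 to compound 2 (0.43 log units; beyond the scatter), the change being (4-methylpiperazin-1-yl in place of piperidin-1-yl on a saturated chain carbon bound to a double-bonded chain carbon).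

Compound 4 `CN1CCN(C/C=C/C(=O)Nc2cc3c(N4CCCc5ccccc54)ncnc3cc2O[C@@H]2CCOC2)CC1` is not yet measured in this assay. It differs from compound 3 by 4-methylpiperazin-1-yl in place of piperidin-1-yl on a saturated chain carbon bound to a double-bonded chain carbon, the same change as from compound 1 to compound 2, at a place described in identical words; the change thus appears in two pairs of the series, one measured and one open.

Compound 4 is expected to show the step of a 2.7-fold higher number from compound 3 to compound 4 (0.43 log units; beyond the scatter) because the same change gave a 2.7-fold higher number from compound 1 to compound 2 (0.43 log units; beyond the scatter) and because the core change a 1.3-fold higher number from compound 1 to compound 3 (0.11 log units; within the scatter) stays within the scatter, so the second core gives no reason to expect a different size. Compound 4 is therefore estimated at 9900 nM, with a range from 5500 nM to 18000 nM. One measured instance is a thin basis, so the range is kept wide.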

Compound 4, half-maximal inhibitory concentration: 5870 nM
Compound 4: the middle estimate sits 1.7-fold (0.23 log units) above what was measured; the range from low to high includes it.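

Carried to the second core, 4-methylpiperazin-1-yl in place of piperidin-1-yl gives a 1.6-fold higher number from compound 3 to compound 4 (0.20 log units; within the scatter), and in this assay the two steps for this change do not differ: the same change on two cores in this assay, a 2.7-fold higher number (0.43 log units; beyond the scatter) from compound 1 to compound 2 and a 1.6-fold higher number (0.20 log units; within the scatter) from compound 3 to compound 4, 1.7-fold (0.23 log units) apart, within the scatter of two such steps. Oxolan-3-yl in place of methyl on the oxygen, read with 4-methylpiperazin-1-yl in place, gives a 1.3-fold lower number from compound 2 to compound 4 (0.13 log units; within the scatter), and this step likewise does not differ from its counterpart with piperidin-1-yl: the same change on two cores in this assay, a 1.3-fold higher number (0.11 log units; within the scatter) from compound 1 to compound 3 and a 1.3-fold lower number (0.13 log units; within the scatter) from compound 2 to compound 4, 1.7-fold (0.23 log units) apart, within the scatter of two such steps. These two pairs show no difference in the amine step between the two cores, but they do not show that the amine change has a real effect on the second core, where its step stays within the scatter, and they say nothing about any other core.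

Other amines on the saturated chain carbon, such as morpholin-4-yl or dimethylamino, remain open, as does a longer chain carrying the amine. Also open, from the compounds shown here alone, is whether an ether other than methyl or oxolan-3-yl, such as 2-methoxyethyl, would leave the amine step unchanged.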